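Nitro for Carboxymethyl on a Shared Biphenyl-Amide Core

A few compounds are considered here, and "the series" means these few. Any claim that something is new, unique, unknown or untested is made for them only; others in the source may bear on it.

Compound 1 `CCOC(=O)CCCCCOc1cccc(CN(C(=O)c2ccc(-c3ccc4[nH]ccc4c3)cc2)C(C)C)c1` and compound 2 `CCOC(=O)CCCCCOc1cccc(CN(C(=O)c2ccc(-c3cccc(CC(=O)O)c3)cc2)C(C)C)c1` share one core and differ only in the ring hanging from it. In an ADME assay on HEK293 cells (Homo sapiens) for cytotoxicity, read by CellTiter-Glo and resazurin assay, with a stated time of 72 h (on this read-out lower numbers stand for an effect already at smaller amounts and higher numbers for an effect only at larger amounts of compound), compound 1 reaches only a limit of the assay, > 26000 nM. Compound 2 likewise reaches only a limit, > 26000 nM. The step that the two limits leave unreadable from compound 1 to compound 2 therefore cannot be read, and this is what the limit of > 26000 nM in this assay, at which 2 of the 2 values shown sit, records: both known values sit at the same limit, so compound 2 stands nowhere more precisely than at that limit, exactly where compound 1 stands. Compound 3 `CCOC(=O)CCCCCOc1cccc(CN(C(=O)c2ccc(-c3cccc([N+](=O)[O-])c3)cc2)C(C)C)c1` comes from compound 2 through (nitro in place of carboxymethyl on an aromatic carbon). Going by the values given here, no measured step bears on this change in this assay, since the only step in hand is itself unreadable. The step that the limit leaves unreadable from compound 2 to compound 3 is expected to be none beyond the scatter. Compound 3 is therefore estimated at 40000 nM, within 15000 nM to 100000 nM.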

Compound 3, half-maximal effective concentration: > 26000 nM
Compound 3: no number, only a limit; the forecaster's own chance of this, stated with the estimate: 75%; the middle value lies beyond the limit too.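

In this assay compound 3 also reaches only a limit, > 26000 nM. The steps among compound 1, compound 2 and compound 3 therefore cannot be read: the limit of > 26000 nM in this assay, at which 3 of the 3 values shown sit. Going by these compounds, whether changing the ring on the shared core alters the effect in this assay at all stays open.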